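Fluoro to methoxy: expecting no shift in whole-animal activity

The source may hold more compounds than are shown below. What is called first, only, known or untested is meant among the compounds shown, and "the series" means these compounds.

Of the compounds shown here, three built on one shared core have been tested: compound 1 `COc1cc(OC)c(OC)cc1/C=C/COC(=O)/C=C/c1ccc(Br)cc1`, compound 2 `COc1cc(OC)c(OC)cc1/C=C/COC(=O)/C=C/c1ccccc1C(F)(F)F` and compound 3 `COc1cc(OC)c(OC)cc1/C=C/COC(=O)/C=C/c1ccc(F)cc1`. In a functional assay on the whole organism (strain Kunming) with Mus musculus as the target, with a stated time of 0.5 h, at a dose of 300 mg/kg by the intraperitoneal route (on this read-out higher numbers stand for a weaker effect at the one dose given and lower numbers for a stronger effect), compound 1 gives 100%, compound 2 gives 100% and compound 3 gives 100%. Compound 3 therefore stands level with both companions, and none of the three can be called stronger or weaker than another. The measured steps confirm this: no change at the digits printed from compound 1 to compound 3 (within the scatter), no change at the digits printed from compound 2 to compound 3 (within the scatter) and no change at the digits printed from compound 1 to compound 2 (within the scatter).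

Compound 4 `COc1ccc(/C=C/C(=O)OC/C=C/c2cc(OC)c(OC)cc2OC)cc1` is the next compound to be examined and has not yet been measured. It differs from compound 3 in a single place: methoxy in place of fluoro on an aromatic carbon. Going by the values given here, two measured steps bear on this change, since both also alter the substituent on the same aromatic ring of the same core: no change at the digits printed from compound 1 to compound 3 (within the scatter) and no change at the digits printed from compound 2 to compound 3 (within the scatter). Neither the swap of one halogen for another nor the exchange of the whole substituted phenyl group moved the read-out. On that basis no step beyond the scatter is expected, no change at the digits printed from compound 3 to compound 4 (within the scatter). Compound 4 is accordingly estimated at 100%, with a range from 85% to 100%.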

Compound 4, a percentage reported as activity, at one dose (the size of the read-out at that dose, not a potency): 100%
The estimate for compound 4 equals the measured number at the digits printed, within the range that was stated.
By their numbers in this assay, from the lowest: compounds 1, 2, 3 and 4 (each within the scatter of the next).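

At the place on the aromatic ring para to a large group, methoxy brings two heavy atoms and a hydrogen-bond acceptor where fluoro had one heavy atom and no acceptor, and this assay shows no change at the digits printed from compound 3 to compound 4 (within the scatter) for this swap. Going by these compounds alone, the earlier compounds carried only bromo, fluoro or trifluoromethyl on this ring, so compound 4 is the first here whose substituent holds oxygen and no halogen, and the comparison with those other halogen-bearing compounds gives no change at the digits printed from compound 1 to compound 4 (within the scatter) and also no change at the digits printed from compound 2 to compound 4 (within the scatter) in the same read-out. Nothing measured here explains why these changes leave the read-out flat.

The compounds shown leave open whether a group of another kind at this same place, such as an amine, a carboxylic acid or a hydroxyl, would bring the number down and so mark a stronger effect at this dose. They also leave open whether a change elsewhere on the shared core, such as a longer chain in place of the one that carries the ester, would separate compounds that this read-out cannot yet tell apart.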